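This account rests on a few compounds, and the source may have more. Where it says the series, first, only, none or still open, it means among the compounds named here.

Measured in a physicochemical assay for solubility, read by HPLC, in simulated intestinal fluid, with a stated time of 16 h, at pH 6.5, tested at 125 ug/mL; on this read-out higher numbers stand for higher solubility and lower numbers for lower solubility:
- compound 1 `CNC(=O)c1cc(C(=O)NC2CC2)cn([C@H](C)c2ccccc2)c1=O`: 815 ug/mL
- compound 2 `CC(=O)Nc1c(F)cc(C(=O)N[C@H]2CC[C@H](O)CC2)cc1O[C@@H](C)c1ccccc1`: 996 ug/mL
- compound 3 `CNC(=O)c1cc(C(=O)NC2CC2)cn(Cc2cccc3[nH]ccc23)c1=O`: 20 ug/mL

In this assay, compound 1 at 815 ug/mL is level with compound 2 at 996 ug/mL, the gap between them lying within the scatter. Compound 3 at 20 ug/mL is lower than compound 1, and that gap lies well beyond the scatter.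

Next in line is compound 4 `CNC(=O)c1cc(C(=O)NC2CC2)cn([C@@H](C)c2ccccc2)c1=O`. Relative to compound 1 the change is: the two compounds have the same atoms and bonds and differ only in configuration as drawn: 1 of 1 stereo elements differ; a stereocentre at a saturated chain carbon is drawn R in compound 1 and S in compound 4. For the measured compounds named here, no pair of measured compounds differs in one place, so the data give no direct measure of what a change of configuration does to this read-out. Compound 1 at 815 ug/mL is the only anchor, and with nothing leaving or entering, no shift beyond the scatter is expected. The estimated 1.0-fold lower number from compound 1 to compound 4 (0.01 log units; within the scatter) therefore stays within the scatter. For compound 4 the expected value is 800 ug/mL, with an estimated range from 450 ug/mL to 1200 ug/mL.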

Compound 4, solubility: 598 ug/mL
The estimate for compound 4 lay 1.3-fold (0.13 log units) above the measured number; the measured number falls inside the stated range.
By their numbers in this assay, from the lowest: compound 3; then compounds 4, 1 and 2 (each within the scatter of the next).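

In this assay, a 1.4-fold lower number from compound 1 to compound 4 (0.13 log units; within the scatter) gives the first direct measure of a change of configuration in this series, and the pair reads as level. The comparison isolates the stereocentre at the saturated chain carbon, with nothing leaving or entering: the fact that compounds 1 and 4 differ only in the configuration as drawn. For this one pair on this one core, drawing that stereocentre R or S therefore makes no difference beyond the scatter.

From the compounds shown here alone, whether configuration stays equally without consequence once an amine or a carboxylic acid is carried on the group holding this stereocentre remains open. Also open, going by these compounds, is what a longer chain on that carbon would do to the read-out, and whether the two configurations stay level when that chain is present.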